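The source may hold more compounds than are shown below. What is called first, only, known or untested is meant among the compounds shown, and "the series" means these compounds.

Measured in a functional assay on Chorioallantoic membrane (Gallus gallus, strain Leghorn), read by microscopy, with a stated time of 40 h; a higher number here means a weaker inhibitor, a lower number a stronger inhibitor:
compound 1 `CSc1ccc(N(C)c2ncnc3occ(C)c23)cc1`: 520 nM
compound 2 `CNc1ccc(N(C)c2ncnc3occ(C)c23)cc1`: 707 nM
compound 3 `Cc1coc2ncnc(N(C)c3ccc(N(C)C)cc3)c12`: 653 nM

These three numbers do not separate the compounds. Compound 3 sits with the other two, as a 1.3-fold higher number from compound 1 to compound 3 (0.10 log units; within the scatter) and a 1.1-fold lower number from compound 2 to compound 3 (0.03 log units; within the scatter) both lie within the scatter. Compound 4 `Cc1coc2ncnc(N(C)c3ccc([N+](=O)[O-])cc3)c12` keeps the shared core but has nitro in place of dimethylamino on an aromatic carbon and has not yet been measured. Two measured steps exchange the group on that aromatic carbon: a 1.4-fold higher number from compound 1 to compound 2 (0.13 log units; within the scatter) and a 1.3-fold higher number from compound 1 to compound 3 (0.10 log units; within the scatter). Both are within the scatter, so exchanging this group has not yet moved the number in this assay. Neither step introduces nitro, however, so they offer only loose guidance. No step beyond the scatter is therefore expected, and the expected change is a 1.1-fold higher number from compound 3 to compound 4 (0.06 log units; within the scatter) with no firm direction. For compound 4 the estimated value is 750 nM in this assay, with an expected range from 250 nM to 2200 nM as the likely span of the measurement.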

Compound 4, half-maximal inhibitory concentration: 1060 nM
The estimate for compound 4 lay 1.4-fold (0.15 log units) below the measured number; low and high end bracket the measured number.
By their numbers in this assay, from the lowest: compounds 1, 3, 2 and 4 (each within the scatter of the next, the first and the last beyond it).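

In this assay, among these compounds, nitro is the first group on this aromatic carbon to open a step beyond the scatter, with a 2.0-fold higher number from compound 1 to compound 4 (0.31 log units; beyond the scatter) as a modest step, and it does so only against methylsulfanyl. Against the two amino groups the exchange still stays within the scatter, with a 1.5-fold higher number from compound 2 to compound 4 (0.18 log units; within the scatter) and with a 1.6-fold higher number from compound 3 to compound 4 (0.21 log units; within the scatter) as well, so the position can respond to the group placed on it, but nitro cannot be told apart from methylamino or dimethylamino. Nothing available accounts for the separation of nitro from methylsulfanyl.

The compounds shown leave open whether a carboxylic acid, a chlorine atom or a longer alkyl chain on this aromatic carbon would move the number further. They also leave open whether a primary amine would stay with the other amino groups.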